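The source may hold more compounds than are shown below. What is called first, only, known or untested is meant among the compounds shown, and "the series" means these compounds.

Compound 1 `CC(C)(C)OC(=O)NCCCCNC(=O)CN1CN(c2ccccc2)C2(CCN(C(=O)c3ccc(C(C)(C)C)cc3)CC2)C1=O` carries a 3-((tert-butoxycarbonyl)amino)propyl group on the chain that leaves its core, but in an assay on HEK293 cells for displacement of a labelled ligand from NPC1-like intracellular cholesterol transporter 1 (Homo sapiens) (on this read-out higher numbers stand for weaker inhibition and lower numbers for stronger inhibition), compound 1 is reported as "not determined" (no result reported), so no single number is available for it. Two neighbours sharing the same core were measured. Compound 2 `CC1CCCN(C(=O)CN2CN(c3ccccc3)C3(CCN(C(=O)c4ccc(C5CCCCC5)cc4)CC3)C2=O)C1` gives 3600 nM in this assay. Compound 3 `CC(C)(C)OC(=O)NC1CCN(C(=O)CN2CN(c3ccccc3)C3(CCN(C(=O)c4ccc(C5CCCCC5)cc4)CC3)C2=O)CC1` gives 4800 nM in this assay, and these two values lie within the usual scatter of each other, so neither can be called the stronger. Compound 4 `CC(C)(C)c1ccc(C(=O)N2CCC3(CC2)C(=O)N(CC(=O)NCNS(C)(=O)=O)CN3c2ccccc2)cc1` arises from compound 1 through a single change: methanesulfonamido in place of 3-((tert-butoxycarbonyl)amino)propyl on a saturated chain carbon bound to an amide-type nitrogen. Among the compounds with values here, no measured pair shows this change. The step from compound 1 to compound 4 is expected to be small, most likely within the scatter, with no clear direction. Compound 4 is estimated at 5000 nM in this assay, with an expected range from 1500 nM to 20000 nM.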

Compound 4, half-maximal inhibitory concentration: 3200 nM
Compound 4: the middle estimate sits 1.6-fold (0.19 log units) above what was measured; low and high end bracket the measured number.
By their numbers in this assay, from the lowest: compounds 4, 2 and 3 (each within the scatter of the next).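

Within the data shown here, compound 1 has no single number in this assay, so no step from it to compound 4 can be read, and no evidence bears on this result.

The compounds shown leave open whether replacing 3-((tert-butoxycarbonyl)amino)propyl with methanesulfonamido changes inhibition at all.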